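The source may hold more compounds than are shown below. What is called first, only, known or untested is meant among the compounds shown, and "the series" means these compounds.

Working notes on the series. Three compounds have so far been run in an ADME assay for permeability, using PAMPA, at pH 7.4; on this read-out lower numbers stand for lower permeability and higher numbers for higher permeability. Compound 1 `O=C(Nc1ccc(F)c(-c2nc3ccccc3o2)c1)c1cc([N+](=O)[O-])ccc1Cl` gives 366 10^-6 cm/s, compound 2 `O=C(Nc1ccc(F)c(-c2nc3ccccc3s2)c1)c1cc([N+](=O)[O-])ccc1Cl` gives 17 10^-6 cm/s, and compound 3 `Cc1ccc(-c2nc3ccccc3s2)cc1NC(=O)c1cc([N+](=O)[O-])ccc1Cl` gives 41 10^-6 cm/s. Compound 3 stands second highest of the three, nearest to compound 2 and furthest from compound 1, both gaps beyond the scatter.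

Compound 2 and compound 1 differ in one place only, (1,3-benzoxazol-2-yl in place of 1,3-benzothiazol-2-yl on an aromatic carbon), and that change gives a 22-fold higher number from compound 2 to compound 1 (1.33 log units; beyond the scatter). The difference between the core of compound 2 and the core of compound 3 is not broken down here.

Compound 4 `Cc1ccc(-c2nc3ccccc3o2)cc1NC(=O)c1cc([N+](=O)[O-])ccc1Cl` has not yet been measured in this assay. It carries the same kind of change relative to compound 3: 1,3-benzoxazol-2-yl in place of 1,3-benzothiazol-2-yl on an aromatic carbon. The surroundings are not identical: in the first pair the place is ortho to a fluoro group and meta to a large group, whereas in the second it is meta to a large group and para to a methyl group, so the two changes count as the same kind rather than the same.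

Compound 4 is therefore expected to rise relative to compound 3 by about a 7.3-fold higher number from compound 3 to compound 4 (0.86 log units; beyond the scatter), a smaller step than the earlier one, because only compound 2 to compound 1, a 22-fold higher number from compound 2 to compound 1 (1.33 log units; beyond the scatter), supports the direction and the setting differs. The estimate for compound 4 in this assay is 300 10^-6 cm/s, expected to fall between 90 10^-6 cm/s and 800 10^-6 cm/s.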

Compound 4, apparent permeability: "below limit of detection" (no number reported)
Nothing numeric was reported for compound 4, so the estimate cannot be set against anything.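

For the compounds shown here, compound 4 gave "below limit of detection" in this assay, with no number reported, so no step from compound 3 to compound 4 can be read. The compounds shown leave open whether 1,3-benzoxazol-2-yl in place of 1,3-benzothiazol-2-yl does in that pair what it does in a 22-fold higher number from compound 2 to compound 1 (1.33 log units; beyond the scatter). No measurement shown here accounts for the result.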